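This account rests on a few compounds, and the source may have more. Where it says the series, first, only, none or still open, it means among the compounds named here.

Measured so far:
compound 1 `C=CC(=O)Nc1cccc(Cn2nc(-c3ccc(Oc4ccccc4)cc3)cc2C(=O)OCC)c1` gives 7800 nM
compound 2 `C=CC(=O)Nc1cccc(Cn2nc(-c3ccc(Oc4ccccc4)cc3)cc2CO)c1` gives 6000 nM
compound 3 `C/C=C/C(=O)N1CCCC(n2nc(-c3ccc(Oc4ccccc4)cc3)cc2CO)C1` gives 51100 nM

In a functional assay on Z-138 cells (Homo sapiens) for inhibition, read by luminescence and CellTiter-Glo, with a stated time of 72 h (a lower number here means a stronger inhibitor, a higher number a weaker inhibitor), compound 1 stands second highest of the three numbers. Its nearest neighbour is compound 2, reached by a 1.3-fold lower number from compound 1 to compound 2 (0.11 log units; within the scatter). Its furthest is compound 3, whose number lies higher by a margin beyond the scatter.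

Compound 4 `C/C=C/C(=O)Nc1cccc(Cn2nc(-c3ccc(Oc4ccccc4)cc3)cc2C(=O)OCC)c1` differs from compound 1 in one place: prop-1-en-1-yl in place of vinyl on a carbonyl carbon. Going by the values given here, no measured step covers this change directly. Among the compounds with values here, the single measured step, a 1.3-fold lower number from compound 1 to compound 2 (0.11 log units; within the scatter), concerns a different position and stays within the scatter, so it gives no guidance here. Compound 3 also carries a prop-1-en-1-yl group on its carbonyl carbon and gives a higher number than compound 2, but compound 3 differs from compound 2 in more than that one group, so its higher number cannot be laid on the prop-1-en-1-yl group alone. The expected step of a 2.6-fold higher number from compound 1 to compound 4 (0.41 log units; beyond the scatter) therefore points toward a higher number, with wide uncertainty. Compound 4 is expected to give 20000 nM, within a range from 7000 nM to 60000 nM.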

Compound 4, half-maximal inhibitory concentration: 8900 nM
For compound 4 the middle estimate is 2.2-fold (0.35 log units) above the measured one; low and high end bracket the measured number.
By their numbers in this assay, from the lowest: compounds 2, 1 and 4 (each within the scatter of the next); then compound 3.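

In this assay, going by these compounds alone, putting prop-1-en-1-yl in place of vinyl on the carbonyl carbon gives a 1.1-fold higher number from compound 1 to compound 4 (0.06 log units; within the scatter), the first direct reading at this position, and it shows no real difference. Within the data shown here, the one additional carbon in this group therefore costs nothing measurable on the core of compound 1, something the earlier compounds could not show. Nothing measured here offers an explanation for this result.

On these data alone, it remains open whether a larger group on this carbonyl carbon, such as a longer chain or a chain carrying an amine, would also leave the number in place. A single pair on one core also cannot say whether the same swap would behave alike on a different core, such as that of compound 3.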